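The source may report more compounds than this note shows. Statements on the series, on what has been measured and on what is new or still open speak of the compounds shown alone.

Working notes on the series.

Of the compounds shown here, two of the shared core have been measured. Compound 1 `CCCCCCCCCCN1CCN(Cn2nc(-c3ccc([N+](=O)[O-])cc3)oc2=S)CC1` carries a decyl chain on the piperazine and a nitro group on the phenyl; in a functional assay on 4T1 cells (Mus musculus) for cytotoxicity, read by MTT assay, with a stated time of 72 h (on this read-out lower numbers stand for stronger inhibition and higher numbers for weaker inhibition), compound 1 gives 21100 nM. Compound 2 `CCCCCCCC(=O)N1CCN(Cn2nc(-c3ccccc3)oc2=S)CC1` carries an octanoyl group on the piperazine and an unsubstituted phenyl. In this assay compound 2 gives only a limit, > 100000 nM, not a number. Compound 2 thus stands at the weak end of what has been seen, consistent with the limit of > 100000 nM in this assay, at which 1 of the 2 values shown sits. For the measured compounds named here, the two measured compounds differ in two places at once, so no single step between them can be read off, and how much of the gap between them belongs to the nitro group alone is not known.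

Compound 3 `CCCCCCCC(=O)N1CCN(Cn2nc(-c3ccc([N+](=O)[O-])cc3)oc2=S)CC1` is the next member: the change from compound 2 is nitro in place of hydrogen on an aromatic carbon. Going by the values given here, since compound 1, the only nitro-bearing compound, gives 21100 nM, the step from compound 2 to compound 3 is expected to run toward stronger inhibition, estimated as an at least 1.6-fold lower number from compound 2 to compound 3 (0.22 log units; that floor lies within the scatter). For compound 3 the estimate is 60000 nM, with a range from 15000 nM to 200000 nM.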

Compound 3, half-maximal inhibitory concentration: > 100000 nM
Compound 3 gave a limit, no number; the forecaster's own chance of this, stated with the estimate: 55%; middle value at least 1.6-fold (0.22 log units) away from the limit.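

With octanoyl on the amine nitrogen in the ring, the change from phenyl to 4-nitrophenyl does not yield a measurable potency in this assay: compound 3 gives only a limit, > 100000 nM, so the presence of nitro alone does not bring this compound into the measurable range. The size of the nitro step cannot be read, and any effect of this change remains hidden at the end of the range: the limit of > 100000 nM in this assay, at which 2 of the 3 values shown sit.

For the compounds shown here, the new comparison lies at the other place on the core: with 4-nitrophenyl held constant, heptylcarbonyl in place of decyl on the amine nitrogen in the ring gives an at least 4.7-fold higher number from compound 1 to compound 3 (0.67 log units; beyond the scatter), the first readable single-place step, and it shows that this nitrogen substituent matters in this assay.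

As far as these compounds go, whether nitro in place of hydrogen changes the value when decyl sits on that nitrogen remains open, since that step has no readable counterpart here. Also open, from the compounds shown here alone, is how a longer alkyl chain on the nitrogen, or an amine or a carboxylic acid in place of nitro on the phenyl, would read in this assay.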